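Swapping the Aryl Group on a Shared Core

The source may report more compounds than this note shows. Statements on the series, on what has been measured and on what is new or still open speak of the compounds shown alone.

Values in a functional assay, with a stated time of 90 s; a lower number here means a stronger inhibitor, a higher number a weaker inhibitor:

- Compound 1 `Cc1nc2c3ccccc3ccc2c2nc3c(ccc4ccccc43)c(-c3cccc([N+](=O)[O-])c3)c12`: 157 ug/mL
- Compound 2 `Cc1nc2c3ccccc3ccc2c2nc3c(ccc4ccccc43)c(-c3cccnc3)c12`: 156 ug/mL
- Compound 3 `Cc1nc2c3ccccc3ccc2c2nc3c(ccc4ccccc43)c(-c3cccc4ccccc34)c12`: 179 ug/mL

The three compounds share one core and differ only in the aryl group on an aromatic carbon opposite the ring nitrogen. Compound 3, which carries naphthalen-1-yl, gives 179 ug/mL and sits within the scatter of both other compounds. Its measured steps are a 1.1-fold higher number from compound 1 to compound 3 (0.06 log units; within the scatter) and a 1.1-fold higher number from compound 2 to compound 3 (0.06 log units; within the scatter). The remaining step, a 1.0-fold lower number from compound 1 to compound 2 (0.00 log units; within the scatter), also stays within the scatter.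

The next compound is compound 4 `Cc1nc2c3ccccc3ccc2c2nc3c(ccc4ccccc43)c(-c3ccc(O)cc3)c12`, which has 4-hydroxyphenyl in place of naphthalen-1-yl on an aromatic carbon. All three measured steps bear on this change, as each replaces one aryl group with another at the same place, and none moves this assay beyond the scatter. Within the data shown here, none of the measured compounds carries 4-hydroxyphenyl, however, so this group itself remains untested and the expectation is an extrapolation. No step beyond the scatter is expected in either direction, and the expected change is a 1.1-fold lower number from compound 3 to compound 4 (0.05 log units; within the scatter). For compound 4 the estimated value is 160 ug/mL, with an expected range from 90 ug/mL to 260 ug/mL.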

Compound 4, half-maximal inhibitory concentration: 99 ug/mL
For compound 4 the middle estimate is 1.6-fold (0.21 log units) above the measured one, within the range that was stated.
By their numbers in this assay, from the lowest: compounds 4, 2, 1 and 3 (each within the scatter of the next).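

Replacing the two-ring naphthalen-1-yl with the single-ring 4-hydroxyphenyl, which brings a hydrogen-bond donor and a hydrogen-bond acceptor to the carbon opposite the ring nitrogen, gives a 1.8-fold lower number from compound 3 to compound 4 (0.26 log units; within the scatter) in this assay and is the largest step yet seen at this position. The exchanges for the other two aryl groups, a 1.6-fold lower number from compound 2 to compound 4 (0.20 log units; within the scatter) and a 1.6-fold lower number from compound 1 to compound 4 (0.20 log units; within the scatter) as well, also stay inside the scatter, so all four aryl groups now give values that this assay does not separate, even though the new group differs from naphthalen-1-yl in ring count and heavy-atom count. No measurement is available to explain why this position tolerates these exchanges in this assay.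

The compounds shown leave open whether an amine or a carboxylic acid on the aryl group, or a saturated ring such as piperidine in place of the aryl group, would give a step beyond the scatter. They also leave open whether the methyl group on the shared core, present in all four compounds, matters to these values.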